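Replacing a dimethylamide with a dimethylanilide on the shared core

The source may hold more compounds than are shown below. What is called first, only, known or untested is meant among the compounds shown, and "the series" means these compounds.

Compound 1, `C=CC(=O)Nc1ccc(-c2nc(Cl)cc(Nc3ccc(C(=O)Nc4cccc(C)c4)cc3)n2)cc1`: 5390 nM
Compound 2, `C=CC(=O)Nc1ccc(-c2nc(Cl)cc(Nc3ccc(C(=O)N4CCCC4)cc3)n2)cc1`: 10400 nM
Compound 3, `C=CC(=O)Nc1ccc(-c2nc(Cl)cc(Nc3ccc(C(=O)N(C)C)cc3)n2)cc1`: > 50000 nM

The three measured compounds share one core and differ only in the group on the carbonyl carbon. In a functional assay on Ramos cells (Homo sapiens) for antiproliferative activity, read by MTT assay, with a stated time of 48 h (a higher number here means a weaker inhibitor, a lower number a stronger inhibitor), compound 1 gives 5390 nM. Compound 2 gives 10400 nM, and the step of a 1.9-fold higher number from compound 1 to compound 2 (0.29 log units; within the scatter) stays within the scatter. Compound 3 gives only a limit in this assay, > 50000 nM, so its place among the three is known only as being at that limit (the limit of > 50000 nM in this assay, at which 1 of the 3 values shown sits). The steps of an at least 9.2-fold higher number from compound 1 to compound 3 (0.96 log units; beyond the scatter) and an at least 4.8-fold higher number from compound 2 to compound 3 (0.68 log units; beyond the scatter) both run toward weaker inhibition, and both are at least modest.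

Compound 4, `C=CC(=O)Nc1ccc(-c2nc(Cl)cc(Nc3ccc(C(=O)Nc4cc(C)ccc4C)cc3)n2)cc1`, has not yet been measured. It differs from compound 3 by the change ((2,5-dimethylphenyl)amino in place of dimethylamino on a carbonyl carbon). The nearest measured guide is compound 1, which carries the related (3-methylphenyl)amino group on the same carbonyl carbon and gives 5390 nM, while the reverse of that change, seen in an at least 9.2-fold higher number from compound 1 to compound 3 (0.96 log units; beyond the scatter), was at least modest. Compound 4 is therefore expected to sit close to compound 1, with the estimated step of an at least 8.3-fold lower number from compound 3 to compound 4 (0.92 log units; beyond the scatter) running back toward stronger inhibition. The estimate for compound 4 is 6000 nM, with a range from 2500 nM to 15000 nM.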

Compound 4, half-maximal inhibitory concentration: 16800 nM
For compound 4 the middle estimate is 2.8-fold (0.45 log units) below the measured one; measured number outside the range, above it.
By their numbers in this assay, from the lowest: compounds 1, 2 and 4 (each within the scatter of the next, the first and the last beyond it). At a limit, above all of these: compound 3.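

In this assay, (2,5-dimethylphenyl)amino on the carbonyl carbon gives a clear gain over dimethylamino, an at least 2.9-fold lower number from compound 3 to compound 4 (0.47 log units; beyond the scatter), but compound 3 is known only as a limit of the assay: the limit of > 50000 nM in this assay, at which 1 of the 4 values shown sits.

For the compounds shown here, what the earlier compounds did not show is that a small addition to the aromatic ring at this position can be felt: with methyl in place of hydrogen on an aromatic carbon, the result is a 3.1-fold higher number from compound 1 to compound 4 (0.49 log units; beyond the scatter), a modest move toward weaker inhibition, so an aromatic amide here does not by itself hold the level of compound 1. The aromatic ring also brings no separation from the saturated ring once that methyl is present, as a 1.6-fold higher number from compound 2 to compound 4 (0.21 log units; within the scatter) stays within the scatter.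

The compounds shown leave open whether a single methyl group on the aniline ring, as in (2-methylphenyl)amino, would carry the same cost as the pair in compound 4, and the data give no reason for that cost. They also leave open how a morpholin-4-yl group on this carbonyl carbon, or a carboxylic acid or an amine on the aniline ring, would read in this assay.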